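Cytotoxicity of a pyrazolopyridine amidine series on HT-1080 cells

This account rests on a few compounds, and the source may have more. Where it says the series, first, only, none or still open, it means among the compounds named here.

Measured compounds:
Compound 1, `Cn1nc(-c2ccccc2)c2cc(C(=N)Nc3cccc(C(F)(F)F)c3)ncc21`: 17800 nM
Compound 2, `COc1ccc(Cn2nc(-c3ccccc3)c3cc(C(=N)Nc4cccc(C(F)(F)F)c4)ncc32)cc1`: 46700 nM
Compound 3, `CN1CCN(c2ccc(NC(=N)c3cc4c(-c5ccccc5)nn(C)c4cn3)cc2)CC1`: 1400 nM

The three measured compounds were tested in a functional assay on HT-1080 cells (Homo sapiens) for cytotoxicity, read by MTT assay, with a stated time of 72 h; on this read-out higher numbers stand for weaker inhibition and lower numbers for stronger inhibition. Compound 1 gives 17800 nM in this assay, and compound 2 gives 46700 nM. The two differ in one place, marked by 4-methoxyphenyl in place of hydrogen on a saturated chain carbon bound to an aromatic nitrogen, and the change produced a 2.6-fold higher number from compound 1 to compound 2 (0.42 log units; beyond the scatter). Compound 3 gives 1400 nM, the lowest number of the three; its nearest neighbour in value is compound 1, and compound 2 lies furthest from it. Compound 3 and compound 1 differ in more than one place, and the difference between the two cores is not broken down here.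

Compound 4, `COc1ccc(Cn2nc(-c3ccccc3)c3cc(C(=N)Nc4ccc(N5CCN(C)CC5)cc4)ncc32)cc1`, has not been measured in this assay. It stands to compound 3 as compound 2 stands to compound 1: the change is 4-methoxyphenyl in place of hydrogen on a saturated chain carbon bound to an aromatic nitrogen, the same change as from compound 1 to compound 2, at the same place. Because the earlier step was a 2.6-fold higher number from compound 1 to compound 2 (0.42 log units; beyond the scatter), a step of similar size and direction is expected here, so that compound 4 is estimated to give a higher number than compound 3, the expected step being a 2.6-fold higher number from compound 3 to compound 4 (0.41 log units; beyond the scatter). This rests on a single prior example, so the expectation is held loosely. Compound 4 is thus estimated at 3600 nM in this assay, with a range expected from 1500 nM to 9000 nM.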

Compound 4, half-maximal inhibitory concentration: 1090 nM
Compound 4: middle estimate off by 3.3-fold (0.52 log units), on the high side; measured number outside the range, below it.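

In this assay, the change from methyl to 4-methoxybenzyl on the core of compound 3 gave a 1.3-fold lower number from compound 3 to compound 4 (0.11 log units; within the scatter), so this pair cannot be told apart on this read-out. The change therefore did not carry over with one size from the core of compound 1 to the core of compound 3, as the two steps set side by side show: the same change on two cores in this assay, a 2.6-fold higher number (0.42 log units; beyond the scatter) from compound 1 to compound 2 and a 1.3-fold lower number (0.11 log units; within the scatter) from compound 3 to compound 4, 3.4-fold (0.53 log units) apart, beyond the scatter of two such steps. Among the compounds shown here, this shows that the step seen on one core could not be transferred to the other as a fixed increment, but with only two pairs it does not show which difference between the cores is responsible, since compound 1 and compound 3 differ in more than one place, nor what the change would do on any further core.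

The compounds shown carry only methyl or 4-methoxybenzyl at this place, which leaves open how a plain benzyl group or a longer chain would read there. From the compounds shown here alone, it also remains open whether the same change would follow either step on a core carrying a primary amine in place of the trifluoromethyl group.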